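The source may hold more compounds than are shown below. What is called first, only, known or untested is meant among the compounds shown, and "the series" means these compounds.

Working notes on the series.

Compound 1 `COc1ccc(-c2cn(CC(=O)Nc3nccs3)nn2)cc1` carries a 1,3-thiazol-2-yl group on the amide-type nitrogen; in a functional assay on BMDM cells (Mus musculus, strain C57BL/6) for inhibition, with a stated time of 2 days (on this read-out lower numbers stand for stronger inhibition and higher numbers for weaker inhibition), compound 1 gives 510 nM. Compound 2 `COc1ccc(-c2cn(CC(=O)Nc3cc(C)on3)nn2)cc1` differs from it only at that nitrogen, where a 5-methyl-1,2-oxazol-3-yl group sits instead. For compound 2 this assay reports only a limit, > 30000 nM. The change 1,3-thiazol-2-yl in place of 5-methyl-1,2-oxazol-3-yl on an amide-type nitrogen therefore gives an at least 58-fold lower number from compound 2 to compound 1 (1.76 log units; beyond the scatter); the step is open-ended because of the limit of > 30000 nM in this assay, at which 2 of the 3 values shown sit.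

Compound 3 `Cc1cc(NC(=O)Cn2cc(-c3cccc(Cl)c3)nn2)no1` shares the 5-methyl-1,2-oxazol-3-yl amide with compound 2 but differs in the core, a difference that is not broken down here. For compound 3 this assay again reports only a limit, > 30000 nM.

Compound 4 `O=C(Cn1cc(-c2cccc(Cl)c2)nn1)Nc1nccs1` is compound 3 with the same change, (1,3-thiazol-2-yl in place of 5-methyl-1,2-oxazol-3-yl on an amide-type nitrogen); the place lines read alike, so it is the same change as from compound 2 to compound 1. Since compound 3 sits at a limit, the step to compound 4 is expected to be at least as large as the measured one, estimated as an at least 25-fold lower number from compound 3 to compound 4 (1.39 log units; beyond the scatter). Compound 4 is expected to reach about 1200 nM, with a likely range from 300 nM to 6000 nM, resting on compound 1 at 510 nM as the only measured thiazole.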

Compound 4, half-maximal inhibitory concentration: > 30000 nM
Compound 4: a limit, no number; the forecaster's own chance of this, stated with the estimate: 15%; middle value at least 25-fold (1.39 log units) away from the limit.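

Compound 3 and compound 4 both stand at a limit in this assay, so no step between them can be read: the limit of > 30000 nM in this assay, at which 3 of the 4 values shown sit.

The compounds shown leave open whether 1,3-thiazol-2-yl in place of 5-methyl-1,2-oxazol-3-yl changes the read-out at all on the core of compound 3, as it does on the core of compound 1.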